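A few compounds are considered here, and "the series" means these few. Any claim that something is new, unique, unknown or untested is made for them only; others in the source may bear on it.

The measured compounds:
compound 1, `Brc1ccccc1Cn1ccc2nc(-c3ccccc3)nc-2c1`, with > 100000 nM in an ADME assay on MDBK cells (Bos taurus) for cytotoxicity (on this read-out lower numbers stand for higher toxicity in this test and higher numbers for lower toxicity in this test), a limit of the assay and not a number.
compound 2, `N#Cc1ccccc1Cn1ccc2nc(-c3ccccc3)nc-2c1`, with > 100000 nM in this assay, likewise a limit.

In this assay compound 2 stands at the limit of the assay. Both values shown sit at that limit, (the limit of > 100000 nM in this assay, at which 2 of the 2 values shown sit). Among the measured compounds shown here, the one measured step, a step that the two limits leave unreadable from compound 1 to compound 2, is therefore of unreadable size. Compound 3, `c1ccc(-c2nc3ccn(Cc4ccccn4)cc-3n2)cc1`, differs from compound 2 by pyridin-2-yl in place of 2-cyanophenyl on a saturated chain carbon bound to an aromatic nitrogen. For the measured compounds named here, no measured step covers this change, and the single measured step offers no readable size, so no step beyond the scatter is expected in either direction. Compound 3 is expected to stay close to the limit because compound 2 sits there as shown by the limit of > 100000 nM in this assay, at which 2 of the 2 values shown sit, an expected step of a number no higher from compound 2 to compound 3 (the limit leaves the size open). The estimate for compound 3 in this assay is 100000 nM, ranging from 50000 nM to 300000 nM, and most likely the assay will again report only a limit.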

Compound 3, half-maximal cytotoxic concentration: > 100000 nM
Compound 3: a limit, no number (the forecaster's own chance of this, stated with the estimate: 80%); the middle value sits exactly at the limit.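

In this assay compound 3 gives > 100000 nM, again a limit and not a number. No step among compound 1, compound 2 and compound 3 can be read: the limit of > 100000 nM in this assay, at which 3 of the 3 values shown sit.

The compounds shown leave open what size, if any, these changes have on this read-out, and what structure would give a measurable value.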